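Working notes: from compound 2 to compound 3

A few compounds are considered here, and "the series" means these few. Any claim that something is new, unique, unknown or untested is made for them only; others in the source may bear on it.

Measured in a functional assay on SK-OV-3 cells (Homo sapiens) for inhibition, read by CCK-8 assay, with a stated time of 70 h; on this read-out lower numbers stand for stronger inhibition and higher numbers for weaker inhibition:
- compound 1 `c1ccc(COc2ccc(OCCOCCNC3CCCC3)cc2)cc1`: 24800 nM
- compound 2 `Nc1ccccc1COc1ccc(OCCOCCNC2CCCC2)cc1`: 14000 nM

Compound 2, at 14000 nM, stands within the scatter of compound 1, at 24800 nM. Compound 3 `COC(=O)c1ccc(COc2ccc(OCCOCCNC3CCCC3)cc2)cc1` has 4-(methoxycarbonyl)phenyl in place of 2-aminophenyl on a saturated chain carbon bound to an oxygen on an aromatic ring. Among the measured compounds shown here, the only measured step with a bearing is a 1.8-fold lower number from compound 1 to compound 2 (0.25 log units; within the scatter), which puts amino in place of hydrogen on an aromatic carbon. For the measured compounds named here, no measured compound carries the methoxycarbonyl group, so no step beyond the scatter is expected in this assay. The expected change is a 1.1-fold higher number from compound 2 to compound 3 (0.03 log units; within the scatter). For compound 3 the estimate is 15000 nM, with an expected range from 6000 nM to 35000 nM.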

Compound 3, half-maximal inhibitory concentration: 6990 nM
For compound 3 the middle estimate is 2.1-fold (0.33 log units) above the measured one; measured number inside the range.
By their numbers in this assay, from the lowest: compounds 3, 2 and 1 (each within the scatter of the next, the first and the last beyond it).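

In this assay, among the compounds shown here, the step to 4-(methoxycarbonyl)phenyl is the first to pass the scatter: a 3.5-fold lower number from compound 1 to compound 3 (0.55 log units; beyond the scatter) and the methoxycarbonyl group is the one difference. Against 2-aminophenyl the same group stays within the scatter, at a 2.0-fold lower number from compound 2 to compound 3 (0.30 log units; within the scatter) and so these two substituted rings are not told apart here. No measurement bears on why the methoxycarbonyl step has this size.

Going by these compounds, it remains open whether a carboxylic acid or a primary amide in place of methoxycarbonyl would keep this step. Also open, on these data alone, is whether the step depends on the ester group itself or would appear with a nitrile.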